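This account rests on a few compounds, and the source may have more. Where it says the series, first, only, none or still open, it means among the compounds named here.

Measured so far:
compound 1 `COc1ccc2cc(-c3cc4cc(C(C)N(O)C(C)=O)ccc4o3)ccc2c1` — an assay on RBL cells for inhibition of Polyunsaturated fatty acid 5-lipoxygenase (Rattus norvegicus); on this read-out lower numbers stand for stronger inhibition and higher numbers for weaker inhibition: 120 nM
compound 2 `CC(c1ccc2oc(-c3ccccc3)cc2c1)N(O)C(=O)c1ccccc1` — this assay: 4830 nM

Compound 2 stands with the highest of the two numbers; the nearest measured compound, compound 1, sits far lower, and the gap between the two values is beyond the scatter. The two structures differ in more than one place, so nothing is computed for that pair and only the two values themselves are on record.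

Compound 3 `CC(c1ccc2oc(-c3ccccc3)cc2c1)N(O)C(=O)c1cccs1` is the next compound to be measured. It differs from compound 2 by thiophen-2-yl in place of phenyl on a carbonyl carbon. For the measured compounds named here, no step of this kind has been measured, so the expectation rests on compound 2 alone. The change is small, and for compound 3 no step beyond the scatter is expected, the estimated step being a 1.2-fold lower number from compound 2 to compound 3 (0.08 log units; within the scatter). Compound 3 is therefore estimated at 4000 nM, with a range from 1500 nM to 12000 nM.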

Compound 3, half-maximal inhibitory concentration: 250 nM
Compound 3: the middle estimate sits 16-fold (1.20 log units) above what was measured; measured number below the stated range.
By their numbers in this assay, from the lowest: compound 1; then compound 3; then compound 2.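

The group on the carbonyl carbon bonded to the amide-type nitrogen proves a sensitive position: in this assay thiophen-2-yl in place of phenyl gives a 19-fold lower number from compound 2 to compound 3 (1.29 log units; beyond the scatter) from the exchange of one aromatic ring for another. The earlier compounds shown here could not show this, as compound 1 and compound 2 differ in more than one place and gave no single-place step. No measurement on record accounts for the size of this step.

Open, on these data alone, is whether the gain is particular to thiophen-2-yl or also appears with furan-2-yl, thiophen-3-yl or pyridin-2-yl on the same carbonyl carbon. Also open, as far as these compounds go, is whether thiophen-2-yl gives a similar step on the core of compound 1, which carries methyl at that carbonyl carbon.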